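This account rests on a few compounds, and the source may have more. Where it says the series, first, only, none or still open, it means among the compounds named here.

Measured in a functional assay on MCF7 cells (Homo sapiens) for antiproliferative activity, read by MTT assay, with a stated time of 72 h; a lower number here means a stronger inhibitor, a higher number a weaker inhibitor:

- Compound 1 `Nc1nc(N)c2cc(CSC(=S)N3CCN(C4CCCCC4)CC3)ccc2n1`: 6800 nM
- Compound 2 `Nc1nc(N)c2cc(CSC(=S)N3CCN(c4ccc(Cl)c(Cl)c4)CC3)ccc2n1`: 2370 nM

Compound 2 holds the lower of the two numbers. Going by the values given here, the only measured step, a 2.9-fold lower number from compound 1 to compound 2 (0.46 log units; beyond the scatter), is modest and came with 3,4-dichlorophenyl in place of cyclohexyl on an amine nitrogen in a ring. Compound 3 `Nc1nc(N)c2cc(CSC(=S)N3CCN(c4ccc(F)cc4)CC3)ccc2n1` keeps the shared core and carries 4-fluorophenyl in place of 3,4-dichlorophenyl at that same nitrogen: 4-fluorophenyl in place of 3,4-dichlorophenyl on an amine nitrogen in a ring. Among the compounds with values here, no measured step exchanges one substituted phenyl for another, so the data offer only a rough guide to size. In this assay, a small move toward a higher number is expected, with the measured 2.9-fold lower number from compound 1 to compound 2 (0.46 log units; beyond the scatter) as the guide to its size, and it may not clear the scatter. The estimated change is a 1.6-fold higher number from compound 2 to compound 3 (0.21 log units; within the scatter). The expected value for compound 3 is 3800 nM, within an estimated range of 1600 nM to 9000 nM.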

Compound 3, half-maximal inhibitory concentration: 1920 nM
For compound 3 the middle estimate is 2.0-fold (0.30 log units) above the measured one, and the stated range covers the measured number.
By their numbers in this assay, from the lowest: compounds 3 and 2 (each within the scatter of the next); then compound 1.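

In this assay the exchange of one substituted phenyl for another on the amine nitrogen gives a 1.2-fold lower number from compound 2 to compound 3 (0.09 log units; within the scatter) and so does not separate 4-fluorophenyl from 3,4-dichlorophenyl. Replacing cyclohexyl with 4-fluorophenyl at the same nitrogen gives a 3.5-fold lower number from compound 1 to compound 3 (0.55 log units; beyond the scatter) and joins the earlier step from cyclohexyl to 3,4-dichlorophenyl, so the two phenyl groups now stand together apart from cyclohexyl in these three compounds. No measurement at hand gives a reason for this.

The compounds shown leave open whether an unsubstituted phenyl, or a phenyl carrying a methoxy group or a nitrile, would fall with these two groups. They also leave open where a benzyl group on that nitrogen would fall, with the phenyl groups or with cyclohexyl.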